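Furan-3-yl gives way to thiophen-3-yl

A few compounds are considered here, and "the series" means these few. Any claim that something is new, unique, unknown or untested is made for them only; others in the source may bear on it.

In a functional assay on DU-145 cells (Homo sapiens), read by sulforhodamine B assay, with a stated time of 5 days (a lower number here means a stronger inhibitor of growth, a higher number a weaker inhibitor of growth), three compounds on a shared core have been measured: compound 1 (`OC[C@H]1O[C@@H](n2cc(F)c3c(-c4ccco4)ncnc32)[C@H](O)[C@@H]1O`) gives 5 nM and compound 2 (`OC[C@H]1O[C@@H](n2cc(F)c3c(-c4cccs4)ncnc32)[C@H](O)[C@@H]1O`) gives 9 nM while compound 3 (`OC[C@H]1O[C@@H](n2cc(F)c3c(-c4ccoc4)ncnc32)[C@H](O)[C@@H]1O`) gives 5 nM in the same test. Within the data shown here, compound 3 therefore stands level with compound 1, and no step among the three goes beyond the scatter. Compound 4 (`OC[C@H]1O[C@@H](n2cc(F)c3c(-c4ccsc4)ncnc32)[C@H](O)[C@@H]1O`) carries thiophen-3-yl in place of furan-3-yl on an aromatic carbon. The closest guide is the same furan-to-thiophen exchange made with the 2-yl groups, which shows a 1.8-fold higher number from compound 1 to compound 2 (0.26 log units; within the scatter) in this assay as a small step. Furan-3-yl in place of furan-2-yl shows no change at the digits printed from compound 1 to compound 3 (within the scatter) in the same data, so moving the ring attachment made no visible difference. A step beyond the scatter is therefore not expected. The estimated step in this assay is a 1.6-fold higher number from compound 3 to compound 4 (0.20 log units; within the scatter) and takes its direction from the thiophen-2-yl exchange. Compound 4 is estimated at 8 nM with 3 nM to 20 nM as the expected range.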

Compound 4, concentration for 50% growth inhibition: 66 nM
The estimate for compound 4 lay 8.3-fold (0.92 log units) below the measured number; the measured number lies above the stated range.
By their numbers in this assay, from the lowest: compounds 1, 3 and 2 (each within the scatter of the next); then compound 4.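

Among these compounds, with thiophen-3-yl, this position shows for the first time that a single-atom exchange in the ring can matter in this assay: there is a 13-fold higher number from compound 3 to compound 4 (1.12 log units; beyond the scatter), and a 13-fold higher number from compound 1 to compound 4 (1.12 log units; beyond the scatter). The attachment point of the sulfur ring also counts, with a 7.3-fold higher number from compound 2 to compound 4 (0.87 log units; beyond the scatter), whereas moving the attachment of the oxygen ring left no visible change, so neither the ring atom nor the attachment point predicts the result alone, and only their combination in compound 4 stands apart. Nothing available explains this difference.

The compounds shown carry only furan and thiophen rings at this position, so it remains open how a phenyl ring, a pyridine ring or an amine would fare there. Going by these compounds, it also remains open whether a thiazole ring would follow the furan groups or thiophen-3-yl.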